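Methoxy in Place of Trifluoromethyl: Estimating Compound 3

The source may hold more compounds than are shown below. What is called first, only, known or untested is meant among the compounds shown, and "the series" means these compounds.

Measured so far:
compound 1, `CCCc1nc(-c2ccccc2)c(CNCCN2CCN(c3cccc(C)c3)CC2)o1`: 43.1%
compound 2, `CCCc1nc(-c2ccccc2)c(CNCCCN2CCN(c3cccc(C(F)(F)F)c3)CC2)o1`: 51.6%

Of the compounds shown here, two have been tested in an assay on HEK293 cells for inhibition of Voltage-dependent T-type calcium channel subunit alpha-1G (Homo sapiens), read by fluorescence, tested at 10 uM; a higher number here means more inhibition at the concentration tested (going by the name of the read-out), a lower number less inhibition. Compound 1 gives 43.1% in this assay, and compound 2 gives 51.6%. Within the data shown here, compound 2 holds the higher of the two numbers, yet its only neighbour, compound 1, sits within the scatter of it, so the two readings cannot be told apart with confidence.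

Compound 3, `CCCc1nc(-c2ccccc2)c(CNCCCN2CCN(c3cccc(OC)c3)CC2)o1`, awaits measurement. It differs from compound 2 in one place: methoxy in place of trifluoromethyl on an aromatic carbon. Among the measured compounds shown here, no pair of measured compounds shows this particular change, so nothing in the data gives its size or direction. The two measured values both sit in the middle of the range, and nothing suggests that compound 3 should leave it.

Compound 3 is therefore expected to give about 45% in this assay, most likely between 25% and 65%. The estimated step of a number 6.6 percentage points lower from compound 2 to compound 3 (within the scatter) is expected to stay within the usual scatter, with no clear direction.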

Compound 3, a percentage reported as inhibition, at one concentration (the size of the read-out at that concentration, not a potency): 36.4%
For compound 3 the middle estimate is 8.6 percentage points above the measured one; the measured number falls inside the stated range.
By their numbers in this assay, from the lowest: compounds 3, 1 and 2 (each within the scatter of the next, the first and the last beyond it).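

In this assay, methoxy in place of trifluoromethyl on an aromatic carbon, meta to a large group, comes with a number 15.2 percentage points lower from compound 2 to compound 3 (beyond the scatter). Among these compounds, compound 2 and compound 3 form the first measured pair that differs in only one place, and they show that the group on this aromatic carbon can shift the reading by more than the scatter, with the 3-methoxyphenyl compound on the lower side of the 3-(trifluoromethyl)phenyl compound; as a single pair, they establish no trend across other groups. Nothing at hand explains why this change lowers the reading.

The compounds shown leave open whether a chlorine atom, a nitrile or a hydroxyl group on the same aromatic carbon would read closer to trifluoromethyl or to methoxy, and whether a longer chain would alter the size of this step. Compound 1 differs from both compound 2 and compound 3 in more than one place, so its reading cannot be assigned to any single change, and the separate contribution of its chain and its ring substituent remains unresolved.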